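Changing the aryl sulfonate ester of a urea series

The source may report more compounds than this note shows. Statements on the series, on what has been measured and on what is new or still open speak of the compounds shown alone.

Of the compounds shown here, two have so far been measured in a functional assay on HT-29 cells (Homo sapiens) for cytotoxicity, read by sulforhodamine B assay, with a stated time of 48 h; on this read-out lower numbers stand for stronger inhibition and higher numbers for weaker inhibition. Compound 1 `O=C(NCCCCl)Nc1cccc(S(=O)(=O)Oc2ccc(O)cc2)c1` gives 51000 nM in this assay, and compound 2 `CCNC(=O)Nc1cccc(S(=O)(=O)Oc2ccccc2CC)c1` gives 33000 nM. Compound 2 stands at the lowest of the two numbers, yet the gap to compound 1 lies within the scatter of repeated measurements, so the two cannot be told apart. The next compound, compound 3 `CCNC(=O)Nc1cccc(S(=O)(=O)Oc2ccc(O)cc2)c1`, differs from compound 2 in one place: 4-hydroxyphenyl in place of 2-ethylphenyl on an oxygen, the same oxygen attached to the sulfonyl sulfur. Going by the values given here, no step between measured compounds isolates this exchange, so its size is unknown. Given that both measured values sit within the scatter of each other, compound 3 is expected to show no step beyond the scatter, a 1.3-fold higher number from compound 2 to compound 3 (0.10 log units; within the scatter). Compound 3 is estimated at 42000 nM, with a likely range from 18000 nM to 100000 nM.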

Compound 3, half-maximal inhibitory concentration: 75000 nM
The estimate for compound 3 lay 1.8-fold (0.25 log units) below the measured number; the measured number falls inside the stated range.
By their numbers in this assay, from the lowest: compounds 2, 1 and 3 (each within the scatter of the next, the first and the last beyond it).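

On the oxygen attached to the sulfonyl sulfur, 4-hydroxyphenyl in place of 2-ethylphenyl now has a measured size in this assay: a 2.3-fold higher number from compound 2 to compound 3 (0.36 log units; beyond the scatter), a modest step and the first in this series beyond the scatter. Hydrogen in place of chloromethyl on a saturated chain carbon, two bonds along the chain from an amide-type nitrogen, gives a 1.5-fold higher number from compound 1 to compound 3 (0.17 log units; within the scatter), so that exchange cannot be told apart from no change. The data at hand offer no reason for either step. Still open, as far as these compounds go, is whether the higher number goes with the loss of the 2-ethylphenyl or with the arrival of the 4-hydroxyphenyl. An unsubstituted phenyl, a 4-ethylphenyl or a 2-hydroxyphenyl on this oxygen would separate the two, and an amine on the urea chain remains an open question too.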